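A few compounds are considered here, and "the series" means these few. Any claim that something is new, unique, unknown or untested is made for them only; others in the source may bear on it.

Measured compounds:
compound 1 `COc1ccc(COc2ccccc2/C=N/NC(=O)CNC(=O)c2ccc(C)cc2)cc1`: > 50000 nM, which is a limit of the assay rather than a number
compound 2 `O=C(COc1ccc(Cl)cc1)NCc1ccc(CNC(=O)COc2ccc(Cl)cc2)cc1`: 26400 nM

Both were tested in a functional assay on HepG2 cells (Homo sapiens) for inhibition, read by MTT assay, with a stated time of 24 h; a higher number here means a weaker inhibitor, a lower number a stronger inhibitor. Compound 1 gave no number at all in this assay, only the limit > 50000 nM, so where it truly stands is open; what is known is that it sits at the limit of > 50000 nM in this assay, at which 1 of the 2 values shown sits. Compound 2 gives 26400 nM in this assay, a value that also points to little inhibition.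

The compound still to be measured is compound 3 `Cc1ccc(C(=O)NCC(=O)N/N=C/c2ccccc2OCc2ccc(Cl)cc2)cc1`. It differs from compound 1 in one place: chloro in place of methoxy on an aromatic carbon. Among the compounds with values here, no measured pair shows this change, so its effect cannot be read from the data. Compound 2 carries chloro on its aromatic rings and gives 26400 nM, which offers no sign that chloro brings strong inhibition here.

The expected step is therefore an at least 1.1-fold lower number from compound 1 to compound 3 (0.04 log units; that floor lies within the scatter), a move not beyond the scatter and with no clear direction. Compound 3 is expected at about 45000 nM, with a range from 15000 nM to 150000 nM, and a real chance that this assay again reports only a limit.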

Compound 3, half-maximal inhibitory concentration: > 50000 nM
Compound 3 ended at the assay's limit (the forecaster's own chance of this, stated with the estimate: 55%); middle value at least 1.1-fold (0.04 log units) away from the limit.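

In this assay compound 3 gives > 50000 nM, which is a limit and not a number. Compound 1 gives > 50000 nM, also a limit, so no step between compound 1 and compound 3 can be read: the limit of > 50000 nM in this assay, at which 2 of the 3 values shown sit.

The compounds shown leave open whether chloro in place of methoxy changes inhibition, and in which direction.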